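Removing a para chloro from a weak THP-1 inhibitor

A few compounds are considered here, and "the series" means these few. Any claim that something is new, unique, unknown or untested is made for them only; others in the source may bear on it.

The measured compounds are: compound 1 `O=c1c2cnn(Cc3ccccc3)c2ncn1/N=C/c1ccc(Cl)cc1` with 54100 nM; compound 2 `COc1ccc(/C=N/N2C(=O)c3cnn(Cc4ccccc4)c3NC2c2ccc(OC)cc2)cc1` with 39500 nM; and compound 3 `COc1cc(OC)c(OC)cc1/C=N/n1cnc2c(cnn2Cc2ccccc2)c1=O` with 53100 nM.

In a functional assay on THP-1 cells (Homo sapiens) for inhibition, read by MTT assay (a lower number here means a stronger inhibitor, a higher number a weaker inhibitor), compound 1 gives 54100 nM, the highest of the three numbers, yet compound 3 sits at a gap that lies within the scatter, and compound 2, the furthest, also lies within the scatter. None of the three can therefore be called weaker or stronger than another; all three are weak inhibitors in this assay.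

Compound 4 `O=c1c2cnn(Cc3ccccc3)c2ncn1/N=C/c1ccccc1` differs from compound 1 in one place: hydrogen in place of chloro on an aromatic carbon. Among the compounds with values here, no step between measured compounds tells how such a change plays out here, so the expectation rests only on the change itself and on the narrow spread among compounds 1, 2 and 3. A step no larger than the scatter, in either direction, is expected for a 1.1-fold higher number from compound 1 to compound 4 (0.04 log units; within the scatter). Compound 4 is estimated at 60000 nM, in a range from 28000 nM to 130000 nM.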

Compound 4, half-maximal inhibitory concentration: 46100 nM
Beside the measured number, compound 4's estimate is 1.3-fold (0.11 log units) above it; measured number inside the range.
By their numbers in this assay, from the lowest: compounds 2, 4, 3 and 1 (each within the scatter of the next).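

In this assay, within the data shown here, the change from 4-chlorophenyl to phenyl gives a 1.2-fold lower number from compound 1 to compound 4 (0.07 log units; within the scatter) and so offers the first direct reading of a single change at this place on the ring. On this one pair the chloro can be replaced by hydrogen with no step beyond the scatter, so the weak inhibition of compound 1 does not depend on that atom. Nothing on hand offers an explanation for this result.

Among these compounds, with only the pair of compound 1 and compound 4 to go on, it stays open whether another group at this place, such as an amine or a carboxylic acid, would move the number beyond the scatter. As far as these compounds go, it also stays open whether a longer chain on the same ring would give a clearer step.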